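Swapping the aryl ether for a phenylsulfanyl tail

The compounds below may be only part of what the source reports. "The series", "measured", "known", "first", "only" and "open" are said of these compounds alone.

Measured compounds:
compound 1, `COc1cc(C(C)=O)ccc1OCCCN1CCC(C(c2ccccc2)c2ccc(F)cc2)CC1`, 6.31 nM
compound 2, `COc1cc(C(C)=O)ccc1OCCCN1CCC(C(NC(C)=O)(c2ccc(F)cc2)c2ccc(F)cc2)CC1`, 63.1 nM
compound 3, `CCc1ccc(OCCCN2CCC(C(c3ccc(F)cc3)c3ccc(F)cc3)CC2)c(OC)c1`, 2.51 nM

All three were tested in a functional assay (aorta) with Oryctolagus cuniculus as the target; on this read-out lower numbers stand for tighter binding and higher numbers for weaker binding. Compound 3 has the lowest number of the three; its nearest neighbour is compound 1, and the gap between them lies beyond the scatter, while compound 2 stands furthest away, also well beyond the scatter. Compound 3 can therefore be called the tightest binder of this small set.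

Compound 4, `Fc1ccc(C(c2ccc(F)cc2)C2CCN(CCCSc3ccccc3)CC2)cc1`, has not yet been measured. It differs from compound 3 in one place: phenylsulfanyl in place of 4-ethyl-2-methoxyphenoxy on a saturated chain carbon, three bonds along the chain from an amine nitrogen in a ring. The group that enters is smaller than the one that leaves and carries one fewer hydrogen-bond acceptor, as the count shows. Within the data shown here, with no measured pair of this kind to lean on, the expectation is a moderate loss of binding, a step beyond the scatter but not a large one. Compound 4 is expected to give about 10 nM in this assay, most likely between 3 nM and 40 nM, which would mean an estimated step of a 4.0-fold higher number from compound 3 to compound 4 (0.60 log units; beyond the scatter).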

Compound 4, dissociation constant: 3.16 nM
Beside the measured number, compound 4's estimate is 3.2-fold (0.50 log units) above it; measured number inside the range.
By their numbers in this assay, from the lowest: compounds 3, 4 and 1 (each within the scatter of the next, the first and the last beyond it); then compound 2.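

In this assay, putting phenylsulfanyl in place of 4-ethyl-2-methoxyphenoxy gives a 1.3-fold higher number from compound 3 to compound 4 (0.10 log units; within the scatter), so the two compounds cannot be told apart. Among these compounds, this is the first direct comparison at this place on the chain, and it shows that a smaller group with one fewer hydrogen-bond acceptor by the count, joined through sulfur instead of oxygen, can stand there without a change larger than the usual scatter of the measurement. Nothing measured here explains why the two compounds read alike.

The swap changes the linking atom and removes the ethyl and methoxy groups in a single step, so the effects of these changes cannot be separated, and they may even offset each other. A plain phenoxy tail would separate them, while an amine or a carboxylic acid on the phenyl ring would test this place with quite different groups.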